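Series notes: benzimidazole-quinolinone analogues, methyl to methoxy step

The source may hold more compounds than are shown below. What is called first, only, known or untested is meant among the compounds shown, and "the series" means these compounds.

Measured compounds in a functional assay on SK-OV-3 cells (Homo sapiens) for cytotoxicity, read by MTT assay, with a stated time of 48 h; a lower number here means a stronger inhibitor, a higher number a weaker inhibitor:
- compound 1, `Cc1ccc2[nH]c(=O)c(-c3nc4cc([N+](=O)[O-])ccc4[nH]3)cc2c1`, gives > 100000 nM; this is a limit of the assay, not a number.
- compound 2, `Cc1ccc2[nH]c(=O)c(-c3nc4cc(Br)ccc4[nH]3)cc2c1`, gives > 100000 nM; this too is a limit of the assay.
- compound 3, `Cc1ccc2[nH]c(=O)c(-c3nc4cc(F)ccc4[nH]3)cc2c1`, gives > 100000 nM; again a limit of the assay.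

Compound 3 therefore stands on no number of its own; it sits at the limit of > 100000 nM in this assay, at which 3 of the 3 values shown sit, together with the two others. The measured steps, a step that the two limits leave unreadable from compound 1 to compound 2, a step that the two limits leave unreadable from compound 1 to compound 3 and a step that the two limits leave unreadable from compound 2 to compound 3, are all unreadable in size, since each pair is bounded on both sides by the same limit. None of them can be used to gauge how large a substituent change moves this assay.

Compound 4, `COc1ccc2[nH]c(=O)c(-c3nc4cc(F)ccc4[nH]3)cc2c1`, differs from compound 3 by methoxy in place of methyl on an aromatic carbon. Among the compounds with values here, no measured step shares this change, and the three unreadable steps give no lever to read a direction from. Compound 4 is therefore expected to remain in the same region as the three measured compounds, with the step that the limit leaves unreadable from compound 3 to compound 4 only a guess. The estimate for compound 4 is 150000 nM, within a range from 40000 nM to 600000 nM, with a high chance that the assay again reports only a limit.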

Compound 4, half-maximal inhibitory concentration: > 100000 nM
Compound 4 ended at the assay's limit (the forecaster's own chance of this, stated with the estimate: 85%); the middle value does not contradict the limit.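

No new step can be read between compound 3 and compound 4, since both stand only at a limit of the assay: the limit of > 100000 nM in this assay, at which 4 of the 4 values shown sit.

In this assay the compounds shown leave open how far each lies beyond that limit, and whether any change on the shared core gives a measurable value.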